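Moving the chloro substituent on the pyridine ring

This account rests on a few compounds, and the source may have more. Where it says the series, first, only, none or still open, it means among the compounds named here.

Compound 1 `Cc1ccnc(N(CCN(C(C)C)C(C)C)C(=O)N(C)C)c1`: 95%
Compound 2 `Cc1ccc(N(CCN(C(C)C)C(C)C)C(=O)N(C)C)nc1`: 19%
Compound 3 `CC(C)N(CCN(C(=O)N(C)C)c1ccc(Cl)cn1)C(C)C`: 63%

Of the compounds shown here, three have been tested in a functional assay on the whole organism (stomach) for inhibition, with Canis familiaris (Canis lupus familiaris) as the target, at a dose of 20 mg/kg by the oral route; a higher number here means a stronger effect of the compound at the dose given, a lower number a weaker effect. Compound 3 stands second highest of the three; compound 1 lies above it, as the step of a number 32 percentage points lower from compound 1 to compound 3 (beyond the scatter) shows, and compound 2 lies below it, as the step of a number 44 percentage points higher from compound 2 to compound 3 (beyond the scatter) shows.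

Compound 4 `CC(C)N(CCN(C(=O)N(C)C)c1cccc(Cl)n1)C(C)C` has not yet been measured. It differs from compound 3 in one place: 6-chloropyridin-2-yl in place of 5-chloropyridin-2-yl on an amide-type nitrogen.

Within the data shown here, the step that bears most on this change is the one between compound 1 and compound 2, where a methyl group moves from one place on the pyridine ring to another and the read-out in this assay changes by a number 76 percentage points lower from compound 1 to compound 2 (beyond the scatter). Moving a substituent on the ring has thus shifted the number by a large amount, and in compound 4 it is the chloro that moves. Among the measured compounds shown here, a large step in this assay is therefore expected, but its direction cannot be read from the three compounds, since no compound carrying a group at the new place has been tested. Compound 4 is estimated at 45%, with a range from 10% to 85%. This estimate means a step of a number 18 percentage points lower from compound 3 to compound 4 (beyond the scatter).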

Compound 4, a percentage reported as inhibition, in the whole organism at one dose (the size of the read-out at that dose, not a potency): 78%
Compound 4: the middle estimate sits 33 percentage points below what was measured; the measured number falls inside the stated range.
By their numbers in this assay, from the lowest: compound 2; then compound 3; then compound 4; then compound 1.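

Among these compounds, exchanging 5-chloropyridin-2-yl for 6-chloropyridin-2-yl on the amide-type nitrogen gives a number 15 percentage points higher from compound 3 to compound 4 (beyond the scatter) in this assay, which is the first reading of a group at this new place and shows that the chloro keeps a clear effect there, with a modest gain over the earlier chloro compound. The new compound also stands well clear of the 5-methylpyridin-2-yl compound, with a number 59 percentage points higher from compound 2 to compound 4 (beyond the scatter), yet it stays short of the 4-methylpyridin-2-yl compound, with a number 17 percentage points lower from compound 1 to compound 4 (beyond the scatter), so among these four compounds the chloro at this place does not reach the top of the series. No evidence given here bears on why the read-out shifts with the place of the chloro.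

The compounds shown leave open whether this gain belongs to the chloro itself or to any group at this place, a question that 6-methylpyridin-2-yl on the same nitrogen would address. Also open, on these data alone, is how a methoxy or an amino group would fare in place of that chloro, and whether the order seen at this single dose would hold at other doses.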